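The source may hold more compounds than are shown below. What is called first, only, known or untested is meant among the compounds shown, and "the series" means these compounds.

Measured in a functional assay on OVCAR-4 cells (Homo sapiens) for inhibition, read by colorimetric assay and sulforhodamine B assay, with a stated time of 48 h; a lower number here means a stronger inhibitor of growth, a higher number a weaker inhibitor of growth:
- compound 1 `CCCCCCCCCCCC[C@@H](O)[C@H]1CC[C@H]([C@H](O)CCCCCCCCCCNC(=O)c2ccco2)O1` gives 15800 nM
- compound 2 `CCCCCCCCCCCC[C@@H](O)[C@H]1CC[C@H]([C@H](O)CCCCCCCCCCNC(=O)c2ccoc2)O1` gives 74100 nM
- compound 3 `CCCCCCCCCCCC[C@@H](O)[C@H]1CC[C@H]([C@H](O)CCCCCCCCCCNC(=O)c2cncs2)O1` gives 100000 nM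

Compound 3 stands clearly apart from compound 1, with a 6.3-fold higher number from compound 1 to compound 3 (0.80 log units; beyond the scatter). Against compound 2 there is only a 1.3-fold higher number from compound 2 to compound 3 (0.13 log units; within the scatter), so these two cannot be told apart.

Compound 4 `CCCCCCCCCCCC[C@@H](O)[C@H]1CC[C@H]([C@H](O)CCCCCCCCCCNC(=O)c2ccsc2)O1` has not yet been measured. It keeps the rest of compound 3 and carries thiophen-3-yl in place of 1,3-thiazol-5-yl on a carbonyl carbon.

The useful precedents are the other ring swaps at this same place. Replacing the furan-2-yl group gave a 4.7-fold higher number from compound 1 to compound 2 (0.67 log units; beyond the scatter), a modest step, and the swap between the other two rings gave a 1.3-fold higher number from compound 2 to compound 3 (0.13 log units; within the scatter). The closest named relative of the new group is the furan-3-yl group of compound 2, which gives 74100 nM. No thiophene has been measured in this set, so the forecast is uncertain. A modest move toward a lower number seems most likely, though a result within the scatter would be no surprise. In this assay the expected change is a 2.2-fold lower number from compound 3 to compound 4 (0.35 log units; beyond the scatter). For compound 4 the estimated value is 45000 nM, with an expected range from 15000 nM to 100000 nM.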

Compound 4, concentration for 50% growth inhibition: 1700 nM
For compound 4 the middle estimate is 26-fold (1.42 log units) above the measured one; the whole stated range lies above it.
By their numbers in this assay, from the lowest: compound 4; then compound 1; then compounds 2 and 3 (each within the scatter of the next).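

In this assay, the ring on the carbonyl carbon turns out to matter far more than the earlier swaps suggested: thiophen-3-yl in place of 1,3-thiazol-5-yl brings a large step (a 59-fold lower number from compound 3 to compound 4 (1.77 log units; beyond the scatter)), and thiophen-3-yl in place of furan-3-yl brings another (a 44-fold lower number from compound 2 to compound 4 (1.64 log units; beyond the scatter)). Thiophen-3-yl also moves past furan-2-yl, previously the lowest number in the set (a 9.3-fold lower number from compound 1 to compound 4 (0.97 log units; beyond the scatter)), so compound 4 now has the lowest number of the four and shows that this place can tolerate much stronger growth inhibition than the earlier rings reached. Neither ring sulfur nor a single ring hetero atom accounts for this alone, as compound 3 also carries a ring sulfur and compound 2 also has a single ring hetero atom, yet both remain far weaker than compound 4.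

The compounds shown leave open how a thiophen-2-yl group or a plain phenyl ring would behave on this carbonyl carbon, and so whether the result is specific to thiophen-3-yl. No measurement here bears on why thiophen-3-yl differs so sharply from the other rings.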